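The source may report more compounds than this note shows. Statements on the series, on what has been measured and on what is new or still open speak of the compounds shown alone.

Measured in a functional assay on DU-145 cells (Homo sapiens) for inhibition, read by sulforhodamine B assay, with a stated time of 48 h; a higher number here means a weaker inhibitor of growth, a lower number a stronger inhibitor of growth:
compound 1 `O=C(Nc1cccc(-n2cc(-c3ccncc3)c(-c3ccc(Cl)c(O)c3)n2)c1)Nc1ccc(Cl)c(Cl)c1` gives 1500 nM
compound 2 `COc1cc(-c2nn(-c3cccc(NC(=O)c4ccc(Cl)c(C(F)(F)F)c4)c3)cc2-c2ccncc2)ccc1Cl` gives 6390 nM
compound 3 `O=C(Nc1cccc(-n2cc(-c3ccncc3)c(-c3ccc(Cl)c(O)c3)n2)c1)Nc1cc(C(F)(F)F)cc(C(F)(F)F)c1` gives 1250 nM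

Compound 2 stands highest of the three numbers in this assay, its gap to compound 1 and to compound 3 lying beyond the scatter in both cases. Compound 1 and compound 3 sit within the scatter of each other.

Compound 4 `COc1cc(-c2nn(-c3cccc(NC(=O)Nc4ccc(Cl)c(C(F)(F)F)c4)c3)cc2-c2ccncc2)ccc1Cl` is not yet measured. It differs from compound 2 in one place: (4-chloro-3-(trifluoromethyl)phenyl)amino in place of 4-chloro-3-(trifluoromethyl)phenyl on a carbonyl carbon. The change brings compound 4 closer in build to compound 1 and compound 3, which both give lower numbers than compound 2 in this assay.

On that basis a downward step is expected a 3.2-fold lower number from compound 2 to compound 4 (0.50 log units; beyond the scatter), beyond the scatter but not large. The estimate for compound 4 in this assay is 2000 nM, expected between 800 nM and 5000 nM.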

Compound 4, concentration for 50% growth inhibition: 1500 nM
Beside the measured number, compound 4's estimate is 1.3-fold (0.12 log units) above it, within the range that was stated.
By their numbers in this assay, from the lowest: compounds 3, 1 and 4 (each within the scatter of the next); then compound 2.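

In this assay, for the compounds shown here, (4-chloro-3-(trifluoromethyl)phenyl)amino in place of 4-chloro-3-(trifluoromethyl)phenyl on the carbonyl carbon gives a 4.3-fold lower number from compound 2 to compound 4 (0.63 log units; beyond the scatter), the only one-place step so far. The number at this position therefore responds to the added amino link, with the substituted phenyl ring and the rest of compound 2 unchanged. No measurement shown accounts for the step. Still open, going by these compounds, is whether a methylene or an ether oxygen in place of the amino link would give a similar step. On these data alone, whether an N-methyl amino link would keep it is also open.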